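The source may report more compounds than this note shows. Statements on the series, on what has been measured and on what is new or still open speak of the compounds shown alone.

Measured so far in an ADME assay on Vero cells (Chlorocebus sabaeus) for cytotoxicity, read by MTT assay, with a stated time of 48 h; on this read-out higher numbers stand for weaker inhibition and lower numbers for stronger inhibition:
- compound 1 `CS(=O)(=O)OC1CCC(CN2CCN(c3cc(=O)c4cc(C(F)(F)F)cc([N+](=O)[O-])c4s3)CC2)CC1`: > 64 ug/mL
- compound 2 `CC(C)S(=O)(=O)OC1CCC(CN2CCN(c3cc(=O)c4cc(C(F)(F)F)cc([N+](=O)[O-])c4s3)CC2)CC1`: > 64 ug/mL

In this assay compound 2 gives > 64 ug/mL, which is a limit and not a number. Among the measured compounds shown here, its one neighbour in the data is also only a limit, so compound 2 cannot be ranked. What the measurements hold is the limit of > 64 ug/mL in this assay, at which 2 of the 2 values shown sit.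

Compound 3 `O=c1cc(N2CCN(CC3CCC(OS(=O)(=O)c4ccc5ccccc5c4)CC3)CC2)sc2c([N+](=O)[O-])cc(C(F)(F)F)cc12` has naphthalen-2-yl in place of isopropyl on a sulfonyl sulfur. The shared core and the rest of the molecule stay the same.

For the measured compounds named here, the only measured change at this place is a step that the two limits leave unreadable from compound 1 to compound 2. That step has no readable size, so it gives neither a size nor a direction to carry over. Going by the values given here, the new group is clearly larger than the one in that step, which leaves some chance of a real move. Even so, with no measured step to point to, no shift beyond the usual scatter is expected in this assay.

The step expected is a number no higher from compound 2 to compound 3 (the limit leaves the size open). For compound 3 the estimated value is 64 ug/mL, with an expected range from 25 ug/mL to 128 ug/mL. A report of only a limit again would be the most likely outcome.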

Compound 3, half-maximal inhibitory concentration: > 64 ug/mL
Compound 3: a limit, no number; the forecaster's own chance of this, stated with the estimate: 65%; the middle value lies on the limit itself.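

In this assay, among the compounds shown here, compound 3 gives only a limit, so no step from compound 1 or compound 2 to compound 3 can be read: the limit of > 64 ug/mL in this assay, at which 3 of the 3 values shown sit. The compounds shown leave open where the true values of compound 1, compound 2 and compound 3 lie, and whether methyl, isopropyl or naphthalen-2-yl on a sulfonyl sulfur makes any difference.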